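The source may report more compounds than this note shows. Statements on the series, on what has been measured and on what is new or still open speak of the compounds shown alone.

Measured compounds:
compound 1, `CCOc1ccc2nc(C)cc(OCC(=O)Nc3cc(C)cc(C)c3)c2c1`, > 100000 nM
compound 2, `COc1ccc2nc(C(F)(F)F)cc(OCC(=O)Nc3cc(C)cc(C)c3)c2c1`, > 100000 nM

Both values come from a toxicity assay on HepG2 cells (Homo sapiens) for inhibition, read by CellTiter-Glo, with a stated time of 48 h; on this read-out higher numbers stand for weaker inhibition and lower numbers for stronger inhibition. For compound 2 the value > 100000 nM is a limit of the assay, not a measured number. For compound 1 the value > 100000 nM is likewise a limit. Compound 2 therefore stands exactly where every value shown stands: the limit of > 100000 nM in this assay, at which 2 of the 2 values shown sit. Compound 3, `CCOc1ccc2nc(C(F)(F)F)cc(OCC(=O)Nc3cc(C)cc(C)c3)c2c1`, is not yet measured. Set against compound 2 it shows (methyl in place of hydrogen on a saturated chain carbon bound to an oxygen on an aromatic ring); read one bond further out, methoxy becomes ethoxy. No measured step between two compounds is shown, so no size of step can be taken from the data. Since compound 1 and compound 2 both sit at the limit, the change expected from compound 2 to compound 3 is none beyond the scatter, given as a number no higher from compound 2 to compound 3 (the limit leaves the size open). Compound 3 is thus expected to give about 100000 nM in this assay, within 40000 nM to 300000 nM, most likely again reported as a limit rather than a number.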

Compound 3, half-maximal inhibitory concentration: > 100000 nM
Compound 3 was reported as a limit (the forecaster's own chance of this, stated with the estimate: 85%); the middle value sits exactly at the limit.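

In this assay no step can be read from compound 2 to compound 3 or from compound 1 to compound 3, since all three results are limits of the assay: the limit of > 100000 nM in this assay, at which 3 of the 3 values shown sit.

The compounds shown leave open how large these steps are, and which change to the shared core would give a measurable number.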